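Aryl swap on the benzyloxy arm: compound 4

A few compounds are considered here, and "the series" means these few. Any claim that something is new, unique, unknown or untested is made for them only; others in the source may bear on it.

The series keeps the core of compound 1 `CCOC(=O)c1c(C)nc(-c2cccc(C#N)c2)n1OCC(N)=O` and varies the group on a saturated chain carbon bound to an oxygen on an aromatic ring. In a functional assay on a cell-free system (plasma, Oryctolagus cuniculus) for inhibition, with stated times of 5 min, 1 min and 6 min (a higher number here means a weaker inhibitor, a lower number a stronger inhibitor), compound 1 gives > 30000 nM, a limit of the assay rather than a number. Compound 2 `CCOC(=O)c1c(C)nc(-c2cccc(C#N)c2)n1OCCC(=O)O` gives > 30000 nM in this assay, again a limit. Going by the values given here, compound 3 `CCOC(=O)c1c(C)nc(-c2cccc(C#N)c2)n1OCc1ccc(F)cc1` is the only compound with a number, 5880 nM, and the steps of an at least 5.1-fold lower number from compound 1 to compound 3 (0.70 log units; beyond the scatter) and an at least 5.1-fold lower number from compound 2 to compound 3 (0.70 log units; beyond the scatter) are both bounded by the limit of > 30000 nM in this assay, at which 2 of the 3 values shown sit. Compound 4 `CCOC(=O)c1c(C)nc(-c2cccc(C#N)c2)n1OCc1cccc(C#N)c1` differs from compound 3 by 3-cyanophenyl in place of 4-fluorophenyl on a saturated chain carbon bound to an oxygen on an aromatic ring. Among the compounds with values here, no measured step swaps one aryl group for another; the two known steps only set an aryl group against small polar groups. For compound 4 the expected step is therefore a 1.1-fold lower number from compound 3 to compound 4 (0.03 log units; within the scatter), none beyond the scatter. Compound 4 is estimated at 5500 nM, between 2000 nM and 16000 nM.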

Compound 4, half-maximal inhibitory concentration: > 30000 nM
Compound 4 ended at the assay's limit; the forecaster's own chance of this, stated with the estimate: 12%; at least 5.4-fold (0.73 log units) between middle value and limit.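

Compound 4 gives > 30000 nM in this assay, a limit of the assay and not a number. This first aryl-for-aryl step at this position, an at least 5.1-fold higher number from compound 3 to compound 4 (0.70 log units; beyond the scatter), shows that an aryl group on the saturated chain carbon does not by itself keep a readable number. The steps from compounds 1 and 2 to compound 4 cannot be read, and compound 3 stays the only compound with a number: the limit of > 30000 nM in this assay, at which 3 of the 4 values shown sit.

Going by these compounds, whether the step follows the nitrile, the place of the substituent or the absence of fluorine stays open. Plain phenyl, 3-fluorophenyl and 4-cyanophenyl at this position would separate these readings.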